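Compound 2 to compound 4: losing the benzyl

The source may hold more compounds than are shown below. What is called first, only, known or untested is meant among the compounds shown, and "the series" means these compounds.

Within the data shown here, in a functional assay on NCI-H460 cells (Homo sapiens) (on this read-out lower numbers stand for stronger inhibition and higher numbers for weaker inhibition), compound 2 `COc1cc(NC(C)CCCNC(=O)NOCc2ccccc2)c2ncccc2c1` gives 21000 nM and compound 3 `COc1cc(NC(C)CCCNC(=O)NCCNC(=O)NCCCC(C)Nc2cc(OC)cc3cccnc23)c2ncccc2c1` gives 18000 nM, so these two sit level within the scatter at the high end of the numbers measured so far. Well apart from compound 2 stands compound 1 `COc1cc(NC(C)CCCNC(=O)NCCCCCO)c2ncccc2c1` at 2000 nM in the same read-out.

Among the measured compounds shown here, the next compound is compound 4 `COc1cc(NC(C)CCCNC(=O)NO)c2ncccc2c1`, which keeps the shared core of compound 2 and carries hydrogen in place of benzyl on an oxygen in the only change between them.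

For the measured compounds named here, one measured step bears on this position: an 11-fold higher number from compound 1 to compound 2 (1.02 log units; beyond the scatter) is large and came with benzyloxy replacing 5-hydroxypentyl on the amide-type nitrogen. That step shows that compound 2 can be improved on by changing this substituent, and that a benzyl-free group ending in hydroxy, as in compound 1, gave the lower number. It is indirect evidence, since no hydroxy placed directly on that nitrogen has been measured.

A move toward a lower number is therefore expected, smaller than the measured step, and for compound 4 the expected change is a 3.0-fold lower number from compound 2 to compound 4 (0.48 log units; beyond the scatter) in this read-out.

For compound 4 the estimated value in this assay is 7000 nM (expected range 2000 nM to 25000 nM).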

Compound 4, half-maximal inhibitory concentration: > 100000 nM
Compound 4 ended at the assay's limit; the forecaster's own chance of this, stated with the estimate: 5%; middle value at least 14-fold (1.15 log units) away from the limit.
By their numbers in this assay, from the lowest: compound 1; then compounds 3 and 2 (each within the scatter of the next). At a limit, above all of these: compound 4.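

In this assay compound 4 stands at > 100000 nM, which is a limit of the assay and not a number: the limit of > 100000 nM in this assay, at which 1 of the 4 values shown sits.

Hydrogen in place of benzyl on this oxygen gives an at least 4.7-fold higher number from compound 2 to compound 4 (0.67 log units; beyond the scatter), so the benzyl of compound 2 is not simply a burden to be removed, as an 11-fold higher number from compound 1 to compound 2 (1.02 log units; beyond the scatter) taken alone might have suggested. Hydroxy in place of 5-hydroxypentyl on the amide-type nitrogen gives an at least 50-fold higher number from compound 1 to compound 4 (1.69 log units; beyond the scatter), so a hydroxy placed directly on that nitrogen does not reproduce compound 1, and the three substituents now rank 5-hydroxypentyl, benzyloxy, hydroxy in order of rising numbers, each step beyond the scatter.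

Going by these compounds, how far compound 4 lies past the limit stays unknown, so the steps to it give only a minimum size. Also open, on these data alone, is whether the value of compound 1 depends on the hydroxy of 5-hydroxypentyl or on its carbon chain, a question that a plain pentyl chain, a 2-hydroxyethyl chain, or an amine or carboxylic acid in place of that hydroxy would bear on.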